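The source may hold more compounds than are shown below. What is called first, only, known or untested is meant among the compounds shown, and "the series" means these compounds.

Measured compounds:
compound 1, `COc1ccc(/C(=N\NC(=O)Nc2nnc(COc3ccc4ccccc4c3)o2)c2ccccc2)cc1`: 300 mg/kg
compound 2, `C/C(=N/NC(=O)Nc1nnc(COc2ccc3ccccc3c2)o1)c1ccc(O)cc1`: 300 mg/kg

In a functional assay on the whole organism (strain Swiss albino) with Mus musculus as the target, in the maximal electroshock model, with a stated time of 4 h (a lower number here means that less compound is needed, a higher number that more compound is needed for the effect), compound 1 gives 300 mg/kg. In this assay compound 2 gives 300 mg/kg, level with compound 1 at the digits shown; the two values lie within the scatter of each other, so nothing separates them. Going by the values given here, no step between these two compounds is counted, as they differ in more than one place.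

Compound 3, `O=C(N/N=C(/c1ccccc1)c1ccc(O)cc1)Nc1nnc(COc2ccc3ccccc3c2)o1`, has not yet been tested in this assay. Its structure differs from compound 2 in one place: phenyl in place of methyl on a carbon with a double bond to nitrogen. Compound 1 carries two aromatic rings on the carbon with the double bond to nitrogen and compound 2 carries one, yet both give the same reading in this assay. The step from compound 2 to compound 3 is therefore expected to be no change at the digits printed from compound 2 to compound 3 (within the scatter), none beyond the scatter. Compound 3 is expected to give 300 mg/kg, within a range of 100 mg/kg to 600 mg/kg.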

Compound 3, minimum effective dose: 300 mg/kg
Estimate against measurement, compound 3: no gap at the digits printed; low and high end bracket the measured number.
By their numbers in this assay, from the lowest: compounds 1, 2 and 3 (each within the scatter of the next).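

In this assay, going by these compounds alone, phenyl in place of methyl on a carbon with a double bond to nitrogen gives no change at the digits printed from compound 2 to compound 3 (within the scatter), the first reading of a change in this place alone, and the added six-membered aromatic ring of carbon only does not separate the two compounds. Hydrogen in place of methyl on an oxygen on an aromatic ring, with phenyl held on that carbon, likewise gives no change at the digits printed from compound 1 to compound 3 (within the scatter), so neither single change moves the reading beyond the scatter. Nothing available explains why these readings stay level.

The compounds shown leave open whether a longer chain or an amine on that carbon would move the minimum effective dose. They also leave open whether a carboxylic acid on the aromatic ring in place of the oxygen would do so.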